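One side group swapped, compound 1 to compound 3

A few compounds are considered here, and "the series" means these few. Any claim that something is new, unique, unknown or untested is made for them only; others in the source may bear on it.

Measured so far in an ADME assay on HEK-293T cells (Homo sapiens) for cytotoxicity, read by CCK-8 assay, with a stated time of 48 h; a higher number here means a weaker inhibitor, a lower number a stronger inhibitor:
- compound 1 `O=C(NCCNS(=O)(=O)c1ccc(-c2ccccc2OCc2cccc(O)c2)s1)Nc1cc(C(F)(F)F)cc(C(F)(F)F)c1` gives > 20000 nM
- compound 2 `Cc1cc(C)cc(NC(=O)NCCNS(=O)(=O)c2ccc(-c3ccccc3OCc3ccccc3)s2)c1` gives > 20000 nM

Compound 1 gives only a limit of the test and not a number, > 20000 nM. Compound 2 likewise gives only a limit, > 20000 nM. So far, every result sits at one point: the limit of > 20000 nM in this assay, at which 2 of the 2 values shown sit.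

Compound 3 `Nc1ccc(Oc2ccccc2-c2ccc(S(=O)(=O)NCCNC(=O)Nc3cc(C(F)(F)F)cc(C(F)(F)F)c3)s2)cc1` has not yet been measured. It keeps the rest of compound 1 but carries 4-aminophenyl in place of 3-hydroxybenzyl on an oxygen on an aromatic ring. Going by the values given here, no measured step shows what such a swap does, so the expectation rests on compound 1 and compound 2 sharing that limit (the limit of > 20000 nM in this assay, at which 2 of the 2 values shown sit). No change beyond the usual scatter is expected in this assay, and the estimated step is a number no higher from compound 1 to compound 3 (the limit leaves the size open). For compound 3 the estimated value is 20000 nM, with an expected range of 8000 nM to 40000 nM.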

Compound 3, half-maximal inhibitory concentration: > 20000 nM
Compound 3 gave a limit, no number; the forecaster's own chance of this, stated with the estimate: 70%; the middle value sits exactly at the limit.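

No step can be read from compound 1 to compound 3, as both give only a limit and not a number in this assay. The compounds shown leave open whether swapping 3-hydroxybenzyl for 4-aminophenyl changes the value at all, as every result sits at one point: the limit of > 20000 nM in this assay, at which 3 of the 3 values shown sit.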